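Benzothiazole oxamates: indole-to-pyrimidine swap at the amide

The source may report more compounds than this note shows. Statements on the series, on what has been measured and on what is new or still open speak of the compounds shown alone.

Measured compounds:
compound 1 `CCOC(=O)C(=O)Nc1nc2ccc(NC(=O)c3ccccc3)cc2s1`, > 50000 nM (a limit of the assay)
compound 2 `CCOC(=O)C(=O)Nc1ccc2nc(NC(=O)c3cc4cc(C)ccc4[nH]3)sc2c1`, 10100 nM
compound 3 `CCOC(=O)C(=O)Nc1ccc2nc(NC(=O)c3cc4cc(CC)ccc4[nH]3)sc2c1`, 25300 nM

Three compounds have numbers in a functional assay on MCF7 cells (Homo sapiens) for antiproliferative activity; a higher number here means that more compound is needed for the effect, a lower number that less compound is needed. Compound 1 `CCOC(=O)C(=O)Nc1nc2ccc(NC(=O)c3ccccc3)cc2s1` reaches only the limit of > 50000 nM in this assay, at which 1 of the 3 values shown sits, and gives no number. Compound 2 `CCOC(=O)C(=O)Nc1ccc2nc(NC(=O)c3cc4cc(C)ccc4[nH]3)sc2c1` has the lowest of the two real numbers, with 10100 nM in this assay. Going by the values given here, compound 3 `CCOC(=O)C(=O)Nc1ccc2nc(NC(=O)c3cc4cc(CC)ccc4[nH]3)sc2c1` lies nearest, at 25300 nM; the step of a 2.5-fold higher number from compound 2 to compound 3 (0.40 log units; beyond the scatter) is the only measured step in the set.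

Compound 4 `CCOC(=O)C(=O)Nc1ccc2nc(NC(=O)c3ncccn3)sc2c1` has not been measured. It differs from compound 2 by pyrimidin-2-yl in place of 5-methyl-1H-indol-2-yl on a carbonyl carbon. Among the compounds with values here, no measured step alters the group on this carbonyl carbon; the only step, a 2.5-fold higher number from compound 2 to compound 3 (0.40 log units; beyond the scatter), changes a substituent on the indole ring itself and so bears on this change only loosely. Removing the whole indole, together with its hydrogen-bond donor, and bringing in the smaller pyrimidin-2-yl is a larger change than the measured one, and the weaker compound 1 shows that a smaller aryl amide at this position can sit at the limit. A step in this assay of at least the size of a 2.5-fold higher number from compound 2 to compound 3 (0.40 log units; beyond the scatter) is therefore expected, towards a higher number, with a fair chance of only a limit.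

Compound 4 is estimated at 30000 nM, in the range 10000 nM to 90000 nM, which amounts to an expected step of a 3.0-fold higher number from compound 2 to compound 4 (0.47 log units; beyond the scatter).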

Compound 4, half-maximal effective concentration: > 50000 nM
Compound 4: no number, only a limit (the forecaster's own chance of this, stated with the estimate: 40%); middle value at least 1.6-fold (0.22 log units) from the limit.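

In this assay, the group on the carbonyl carbon now has a measured step of its own, an at least 4.9-fold higher number from compound 2 to compound 4 (0.69 log units; beyond the scatter), so the read-out depends on this group as a whole and not only on the substituent on the indole ring. Compound 4 gives > 50000 nM, a limit of the assay and not a number. With pyrimidin-2-yl on this carbonyl carbon no number is obtained, and more than one amide in the series now stands at the same limit: the limit of > 50000 nM in this assay, at which 2 of the 4 values shown sit.

The compounds shown do not separate the loss of the indole's hydrogen-bond donor from the loss of its fused ring or the entry of the pyrimidine nitrogens. As far as these compounds go, whether an unsubstituted 1H-indol-2-yl, a pyrrol-2-yl or an aminopyrimidine on this carbonyl carbon would give a number remains open.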